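The source may hold more compounds than are shown below. What is called first, only, known or untested is meant among the compounds shown, and "the series" means these compounds.

Of the compounds shown here, three from one family have been tested in a functional assay on LNCaP cells (Homo sapiens) for cytotoxicity, read by MTT assay, with a stated time of 72 h; a lower number here means a stronger inhibitor, a higher number a weaker inhibitor. Compound 1 `COc1cccc(/C(=C\c2cn(C(C)=O)c3ccc(OCc4ccccc4)cc23)C(=O)O)c1` gives 65100 nM in this assay, compound 2 `COc1ccc(Cn2cc(/C=C(/C(=O)O)c3ccccc3)c3cc(OCc4ccccc4)ccc32)cc1` gives 38200 nM, and compound 3 `COc1ccccc1/C(=C\c1cn(C(C)=O)c2ccc(OCc3ccccc3)cc12)C(=O)O` gives 48500 nM. The three numbers sit close together: the gap between compound 3 and compound 2 and the gap between compound 3 and compound 1 both fall within the scatter, so none of the three can be called stronger or weaker than another. Going by the values given here, the only single-point change among the measured compounds is the one that gives a 1.3-fold lower number from compound 1 to compound 3 (0.13 log units; within the scatter), a swap of where the methoxy group sits on the aromatic ring that produced no shift beyond the scatter.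

Compound 4 `COc1ccc(/C(=C\c2cn(C(C)=O)c3ccc(OCc4ccccc4)cc23)C(=O)O)cc1OC` has not yet been measured. It differs from compound 3 in one place: 3,4-dimethoxyphenyl in place of 2-methoxyphenyl on a double-bonded chain carbon bound to a carbonyl carbon and a double-bonded chain carbon. Among the compounds with values here, this change again concerns only the methoxy substitution on the same aromatic ring, and the one measured step of that kind, from compound 1 to compound 3, stayed within the scatter. On that basis the expected step in this assay is a 1.0-fold higher number from compound 3 to compound 4 (0.01 log units; within the scatter), that is, no change beyond the scatter. Compound 4 is therefore estimated at 50000 nM, with a range from 20000 nM to 125000 nM.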

Compound 4, half-maximal inhibitory concentration: > 100000 nM
Compound 4: a limit, no number (the forecaster's own chance of this, stated with the estimate: 10%); at least 2.0-fold (0.30 log units) between middle value and limit.
By their numbers in this assay, from the lowest: compounds 2, 3 and 1 (each within the scatter of the next). At a limit, above all of these: compound 4.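

In this assay, going by these compounds alone, the change to 3,4-dimethoxyphenyl in place of 2-methoxyphenyl gives an at least 2.0-fold higher number from compound 3 to compound 4 (0.31 log units; beyond the scatter) and is the first step in this family to pass beyond the scatter, so the methoxy pattern on this ring can matter after all. The smaller change, methoxy in place of hydrogen on an aromatic carbon, gives an at least 1.5-fold higher number from compound 1 to compound 4 (0.18 log units; that floor lies within the scatter) and cannot yet be called a loss on its own, which leaves the step from the 2-methoxyphenyl compound as the only firm one. The full size of both steps stays unknown, as compound 4 stands at a limit of the assay and not at a number: the limit of > 100000 nM in this assay, at which 1 of the 4 values shown sits.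

Still open, going by these compounds, is how the number would respond to an amine or a hydroxy group on this ring in place of methoxy, and whether any such group would bring it down rather than up. All of these methoxy steps also sit on one shared core, so they say nothing yet about whether the same change would matter on a different core.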